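Sulfur side chain in a series held at the limit

A few compounds are considered here, and "the series" means these few. Any claim that something is new, unique, unknown or untested is made for them only; others in the source may bear on it.

Three compounds share one core and differ only in the group on sulfur. In a functional assay on HepG2 cells (Homo sapiens) for inhibition, read by MTT assay, with a stated time of 48 h (on this read-out higher numbers stand for weaker inhibition and lower numbers for stronger inhibition), compound 1 (`COc1ccc(-n2c(SC)nnc2-c2cc(OC)c(OC)c(OC)c2)cc1`) gives > 60000 nM as a limit, not a number. Compound 2 (`CCSc1nnc(-c2cc(OC)c(OC)c(OC)c2)n1-c1ccc(OC)cc1`) gives > 60000 nM, also a limit. Compound 3 (`COc1ccc(-n2c(SCc3ccccc3)nnc2-c2cc(OC)c(OC)c(OC)c2)cc1`) gives > 60000 nM, again a limit. The set as a whole stands at the limit of > 60000 nM in this assay, at which 3 of the 3 values shown sit, so compound 3 has no numerical position of its own.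

Compound 4 (`COc1ccc(C(=O)CSc2nnc(-c3cc(OC)c(OC)c(OC)c3)n2-c2ccc(OC)cc2)cc1`) carries (4-methoxyphenyl)carbonyl in place of phenyl on a saturated chain carbon bound to a sulfur. Among the compounds with values here, three measured steps bear on this place: (a step that the two limits leave unreadable from compound 1 to compound 2), (a step that the two limits leave unreadable from compound 1 to compound 3) and (a step that the two limits leave unreadable from compound 2 to compound 3). None supplies a size or a direction to carry over. Compound 4 is therefore expected most probably to remain at the limit in this assay, and any readable value could only lie toward stronger inhibition. The expected change is (an at least 1.5-fold lower number from compound 3 to compound 4 (0.17 log units; that floor lies within the scatter)), a rough estimate with no measured size behind it. The estimate for compound 4 is 40000 nM, with an expected range from 6000 nM to 60000 nM, and a report of only a limit remains the likelier outcome.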

Compound 4, half-maximal inhibitory concentration: 18100 nM
The estimate for compound 4 lay 2.2-fold (0.34 log units) above the measured number; low and high end bracket the measured number.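

Within the data shown here, compound 4 is the first compound to give a readable number in this assay, so this position on a saturated chain carbon bound to a sulfur now has a direction: an at least 3.3-fold lower number from compound 3 to compound 4 (0.52 log units; beyond the scatter), alongside an at least 3.3-fold lower number from compound 2 to compound 4 (0.52 log units; beyond the scatter) and an at least 3.3-fold lower number from compound 1 to compound 4 (0.52 log units; beyond the scatter). The steps among compound 1, compound 2 and compound 3 still cannot be read, so hydrogen, methyl and phenyl on this carbon cannot be ordered, and only (4-methoxyphenyl)carbonyl stands apart from them. The three steps to compound 4 give floors and not full sizes, because each starts from a compound held at the limit: the limit of > 60000 nM in this assay, at which 3 of the 4 values shown sit.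

Compound 4 brings in the carbonyl and the 4-methoxyphenyl ring together, so the compounds shown do not say which part goes with the step, and a plain phenylcarbonyl group on the same carbon would be needed to separate them. As far as these compounds go, how a carboxylic acid or an amine on this saturated chain carbon would read in this assay also stays open.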